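A few compounds are considered here, and "the series" means these few. Any claim that something is new, unique, unknown or untested is made for them only; others in the source may bear on it.

Measured in an assay on HEK293 cells for displacement of a labelled ligand from Urotensin-2 receptor (Homo sapiens); on this read-out lower numbers stand for stronger inhibition and higher numbers for weaker inhibition: compound 1 `Cn1cnc2c(NC(=O)NCCN3CCC(O)(Cc4ccccc4)CC3)ccnc21` gives 2140 nM. Compound 2 `O=C(NCCN1CCC(O)(Cc2ccccc2)CC1)Nc1ccnc2c(Br)csc12` gives 3220 nM. Compound 3 `Cc1ccccc1CC1(O)CCN(CCNC(=O)Nc2ccnc3ccsc23)CC1` gives 20 nM.

Compound 3 stands lowest of the three; compound 1 is nearest and compound 2 furthest, both beyond the scatter. Compound 4 `O=C(NCCN1CCC(O)(Cc2cccc(Br)c2)CC1)Nc1ccnc2ccsc12` is compound 3 with 3-bromophenyl in place of 2-methylphenyl on a saturated chain carbon bound to a saturated ring carbon. Among the measured compounds shown here, the only step between measured pairs, a 1.5-fold higher number from compound 1 to compound 2 (0.18 log units; within the scatter), alters the group on the amide-type nitrogen, not the ring in this place, so no measured step bears on the present change. Compounds 1 and 2 carry the plain ring here but also differ from compound 3 on the amide side, so their numbers cannot be read on this change alone. Only a modest shift is anticipated. Compound 4 is expected at 60 nM (range 15 nM to 300 nM), a step of a 3.0-fold higher number from compound 3 to compound 4 (0.48 log units; beyond the scatter) toward weaker binding.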

Compound 4, half-maximal inhibitory concentration: 42 nM
The estimate for compound 4 lay 1.4-fold (0.15 log units) above the measured number; the range from low to high includes it.
By their numbers in this assay, from the lowest: compound 3; then compound 4; then compounds 1 and 2 (each within the scatter of the next).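

In this assay, 3-bromophenyl in place of 2-methylphenyl on a saturated chain carbon bound to a saturated ring carbon gives a 2.1-fold higher number from compound 3 to compound 4 (0.32 log units; beyond the scatter), a modest step that is nevertheless beyond the scatter. This place therefore tolerates a change in both the substituent and its placement on the phenyl ring, with binding kept in the same broad range. No supporting measurement accounts for the size of this step.

The pair cannot separate the effect of the substituent from that of its placement. From the compounds shown here alone, how an amine or a carboxylic acid on this phenyl ring would read also remains open.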